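Ester to acid at the anilino side chain of compound 3

The source may report more compounds than this note shows. Statements on the series, on what has been measured and on what is new or still open speak of the compounds shown alone.

Compounds measured so far:
compound 1, `COc1ccc(CS(=O)(=O)/C=C/c2c(OC)cccc2OC)cc1[N+](=O)[O-]`, 20000 nM in a functional assay on DU-145 cells (Homo sapiens) for cytotoxicity, read by trypan blue exclusion, with a stated time of 96 h; a higher number here means a weaker inhibitor, a lower number a stronger inhibitor
compound 2, `COc1ccc(CS(=O)(=O)/C=C/c2c(OC)cc(O)cc2OC)cc1[N+](=O)[O-]`, 5000 nM
compound 3, `COC(=O)C(Nc1cc(CS(=O)(=O)/C=C/c2c(OC)cc(OC)cc2OC)ccc1OC)c1ccccc1`, 75 nM

Compound 3 stands lowest of the three numbers in this assay. Its nearest neighbour is compound 2, and the gap between them lies beyond the scatter; the gap to compound 1 is wider still. Within the data shown here, the only single-point step among the measured compounds is a 4.0-fold lower number from compound 1 to compound 2 (0.60 log units; beyond the scatter), which concerns a hydroxy in place of hydrogen on an aromatic carbon and touches neither the nitrogen bearing the side chain nor the ester.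

Compound 4, `COc1ccc(C(Nc2cc(CS(=O)(=O)/C=C/c3c(OC)cc(OC)cc3OC)ccc2OC)C(=O)O)cc1`, differs from compound 3 in one place: carboxy(4-methoxyphenyl)methyl in place of methoxycarbonyl)(benzyl on a nitrogen on an aromatic ring. Among the measured compounds shown here, no measured pair shows what this change does; the step between compound 1 and compound 2 concerns a different part of the shared core, so it bears on compound 4 only indirectly, by showing that changes here tend to move the numbers modestly rather than greatly. With no direct comparison, the expected step in this assay is small and of uncertain direction, most likely within or just beyond the scatter, and compound 4 is therefore expected to land near compound 3, with a 2.0-fold higher number from compound 3 to compound 4 (0.30 log units; within the scatter) as the estimated step. The estimate for compound 4 in this assay is 150 nM, within a range of 40 nM to 600 nM.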

Compound 4, half-maximal inhibitory concentration: 100 nM
Estimate against measurement, compound 4: 1.5-fold (0.18 log units) above; the range from low to high includes it.
By their numbers in this assay, from the lowest: compounds 3 and 4 (each within the scatter of the next); then compound 2; then compound 1.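

In this assay, putting carboxy(4-methoxyphenyl)methyl in place of methoxycarbonyl)(benzyl on the nitrogen gives a 1.3-fold higher number from compound 3 to compound 4 (0.12 log units; within the scatter), so compound 3 and compound 4 cannot be told apart in this read-out. Among these compounds, this is the first direct reading at this nitrogen, and it shows that a free carboxylic acid and a methoxy group on the phenyl ring, introduced together in place of the methyl ester and the plain phenyl, leave the number within the scatter. No measurement at hand accounts for this result.

The step carries two edits at once, so the compounds shown leave open how the carboxylic acid would read with the plain phenyl ring, how the 4-methoxyphenyl group would read with the methyl ester kept, and whether the two edits offset each other or each does little. Also open, as far as these compounds go, is whether a primary amide or an amine in place of the carboxy group, or a longer chain carrying it, would hold the number in the same range.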